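Replacing 4-hydroxyphenyl on a saturated ring carbon

The compounds below may be only part of what the source reports. "The series", "measured", "known", "first", "only" and "open" are said of these compounds alone.

For the measured compounds named here, in a functional assay on HCT-116 cells (Homo sapiens) for cytotoxicity, read by MTT assay, with a stated time of 48 h (on this read-out lower numbers stand for stronger inhibition and higher numbers for weaker inhibition), compound 2 `COc1cc(/C=C/C(=O)C2=C(/C=C/c3ccc(O)c(OC)c3)NC(=O)NC2c2ccc(O)cc2)ccc1O` gives 100000 nM, the highest of the two numbers so far, while compound 1 `COc1cc(/C=C/C(=O)C2=C(/C=C/c3ccc(O)c(OC)c3)NC(=O)NC2c2ccccc2)ccc1O` gives 25000 nM. Compound 3 `COc1cc(/C=C/C(=O)C2=C(/C=C/c3ccc(O)c(OC)c3)NC(=O)NC2c2c(Cl)cccc2Cl)ccc1O` carries 2,6-dichlorophenyl in place of 4-hydroxyphenyl on a saturated ring carbon. Going by the values given here, the one relevant measured step, a 4.0-fold higher number from compound 1 to compound 2 (0.60 log units; beyond the scatter), is modest but beyond the scatter and came with hydroxy in place of hydrogen on an aromatic carbon. Among the compounds with values here, compound 3 lacks that hydroxy, so a lower number of similar size is expected, although no measured compound carries chlorine. The expected change is a 5.0-fold lower number from compound 2 to compound 3 (0.70 log units; beyond the scatter). The estimate for compound 3 is 20000 nM, with an expected range of 6000 nM to 70000 nM.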

Compound 3, half-maximal inhibitory concentration: 50000 nM
Compound 3: middle estimate off by 2.5-fold (0.40 log units), on the low side; the range from low to high includes it.
By their numbers in this assay, from the lowest: compounds 1, 3 and 2 (each within the scatter of the next, the first and the last beyond it).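

In this assay, 2,6-dichlorophenyl in place of 4-hydroxyphenyl on the saturated ring carbon gives a 2.0-fold lower number from compound 2 to compound 3 (0.30 log units; within the scatter) and 2,6-dichlorophenyl in place of phenyl gives a 2.0-fold higher number from compound 1 to compound 3 (0.30 log units; within the scatter), so compound 3 cannot be separated from either neighbour. Chlorine on this aromatic ring therefore adds a group at this position without a step beyond the scatter, and only compound 1 and compound 2 remain apart beyond it. No supporting data bear on this result.

Going by these compounds, whether an amine or a carboxylic acid on this aromatic ring would give a step beyond the scatter remains open. Also open, on these data alone, is whether a saturated group such as cyclohexyl would be tolerated on this ring carbon.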